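The source may hold more compounds than are shown below. What is called first, only, known or untested is meant among the compounds shown, and "the series" means these compounds.

Of the compounds shown here, three sharing one core have been measured in a functional assay on L132 cells (Homo sapiens) for cytotoxicity, read by MTT assay, with a stated time of 72 h; a lower number here means that less compound is needed, a higher number that more compound is needed for the effect. Compound 1 `O=C1/C(=C\c2c(Cl)cccc2Cl)c2ccccc2N1c1c(Cl)cccc1Cl` gives in this assay > 100 ug/mL, which is a limit of the assay rather than a number. Compound 2 `COc1ccc(/C=C2\C(=O)N(c3c(Cl)cccc3Cl)c3ccccc32)cc1` likewise gives in this assay only a limit, > 100 ug/mL. Compound 3 `O=C1/C(=C\c2cccc(Br)c2)c2ccccc2N1c1c(Cl)cccc1Cl` is the only one with a number, 19 ug/mL, and so stands alone on the numbers shown. The steps of an at least 5.2-fold lower number from compound 1 to compound 3 (0.72 log units; beyond the scatter) and an at least 5.2-fold lower number from compound 2 to compound 3 (0.72 log units; beyond the scatter) are read against the limit of > 100 ug/mL in this assay, at which 2 of the 3 values shown sit, and only bound the change. Compound 4 `O=C1/C(=C\c2cccc(Cl)c2)c2ccccc2N1c1c(Cl)cccc1Cl` differs from compound 3 by chloro in place of bromo on an aromatic carbon. Going by the values given here, no measured step swaps one halogen for another, so the two measured steps bear on it only indirectly; the expected step of a 1.2-fold higher number from compound 3 to compound 4 (0.06 log units; within the scatter) is none beyond the scatter. Compound 4 is therefore expected at 22 ug/mL, in the range 9 ug/mL to 55 ug/mL.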

Compound 4, concentration for half-maximal effect: 16 ug/mL
Compound 4: middle estimate off by 1.4-fold (0.14 log units), on the high side, and the stated range covers the measured number.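

In this assay bromo and chloro on this aromatic carbon, meta to a large group, read alike, with a 1.2-fold lower number from compound 3 to compound 4 (0.07 log units; within the scatter) as the step between them. A second halogen at this position also gives a readable number, with an at least 6.2-fold lower number from compound 2 to compound 4 (0.79 log units; beyond the scatter) and an at least 6.2-fold lower number from compound 1 to compound 4 (0.79 log units; beyond the scatter) as its steps from the two other aryl groups. Those two steps are only bounds: the limit of > 100 ug/mL in this assay, at which 2 of the 4 values shown sit.

The compounds shown leave open whether an amine or a carboxylic acid at this position would keep such a number. They also leave open whether fluoro would read like bromo and chloro.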